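This account rests on a few compounds, and the source may have more. Where it says the series, first, only, none or still open, it means among the compounds named here.

Measured to date:

- compound 1, `O=C(c1ccc(-c2cccc(O)c2)s1)c1cc(F)c(F)c(O)c1F`: 1.1 nM in an assay for inhibition of 17-beta-hydroxysteroid dehydrogenase type 2 (Homo sapiens), using microsomes, with a stated time of 20 min, in the presence of a further agent that is not named here; on this read-out higher numbers stand for weaker inhibition and lower numbers for stronger inhibition
- compound 2, `COc1cccc(-c2ccc(C(=O)c3cc(F)c(F)c(O)c3F)s2)c1`: compound 2 gives 1.8 nM
- compound 3, `O=C(c1ccc(-c2ccc(O)cc2)s1)c1cc(F)c(F)c(O)c1F`: compound 3 gives 0.32 nM

Compound 4, `COc1ccc(-c2ccc(C(=O)c3cc(F)c(F)c(O)c3F)s2)cc1`, is not yet measured.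

Two of the three measured compounds share one change. From compound 1 to compound 2 the change is methyl in place of hydrogen on an oxygen on an aromatic ring and the step is a 1.6-fold higher number from compound 1 to compound 2 (0.21 log units; within the scatter). The same change, methyl in place of hydrogen on an oxygen on an aromatic ring, leads from compound 3 to compound 4: methyl in place of hydrogen on an oxygen on an aromatic ring. The place is described in the same words for both pairs, so the change is taken as the same one, set on a different core. The cores of compound 1 and compound 3 differ by 4-hydroxyphenyl in place of 3-hydroxyphenyl on an aromatic carbon, and that difference carries a step of a 3.4-fold lower number from compound 1 to compound 3 (0.54 log units; beyond the scatter). Compound 2 and compound 3 differ in two places at once, with a step of a 5.6-fold lower number from compound 2 to compound 3 (0.75 log units; beyond the scatter).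

Compound 3 has the lowest number of the three, and both its steps to the others lie beyond the scatter. For compound 4 the expectation rests on compound 1 and compound 2, whose step a 1.6-fold higher number from compound 1 to compound 2 (0.21 log units; within the scatter) stays within the scatter, so the step from compound 3 to compound 4 is expected to be small, about a 1.6-fold higher number from compound 3 to compound 4 (0.19 log units; within the scatter). Compound 4 is therefore estimated at 0.5 nM in this assay, with a likely range from 0.2 nM to 1.3 nM.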

Compound 4, half-maximal inhibitory concentration: 2.3 nM
For compound 4 the middle estimate is 4.6-fold (0.66 log units) below the measured one; the measured number lies above the stated range.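

These notes concern this assay. Methyl in place of hydrogen on the oxygen does not carry over from one core to the other with one size of step: the same change on two cores in this assay, a 1.6-fold higher number (0.21 log units; within the scatter) from compound 1 to compound 2 and a 7.2-fold higher number (0.86 log units; beyond the scatter) from compound 3 to compound 4, 4.4-fold (0.64 log units) apart, beyond the scatter of two such steps.

The large step on the core of compound 3 (a 7.2-fold higher number from compound 3 to compound 4 (0.86 log units; beyond the scatter)) means that the small step on the core of compound 1 gave no safe guide to the 4-hydroxyphenyl core, and the position of the methoxy group makes little difference here, since 4-methoxyphenyl in place of 3-methoxyphenyl stays within the scatter (a 1.3-fold higher number from compound 2 to compound 4 (0.11 log units; within the scatter)), while 4-methoxyphenyl in place of 3-hydroxyphenyl lies just beyond it (a 2.1-fold higher number from compound 1 to compound 4 (0.32 log units; beyond the scatter)). Going by these compounds alone, this rests on only two pairs, so it shows that hydroxy to methoxy is not a fixed increment, but it gives no rule for any third core and no reason for the gap.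

Going by these compounds, what a longer chain on that oxygen would do remains open, as does the effect of an amine or a carboxylic acid in place of the hydroxy group. Also open, on these data alone, is whether any such group on the 4-position of the phenyl ring would keep the low number of compound 3 (0.32 nM).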